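Ethoxy in place of iodo: expected effect on cell inhibition

A few compounds are considered here, and "the series" means these few. Any claim that something is new, unique, unknown or untested is made for them only; others in the source may bear on it.

Measured compounds:
compound 1, `O=C1C=C(Nc2ccc(I)cc2)C(=O)c2c1nc1n2[C@H]2OC[C@@H](O)[C@H]2OC1`: 2300 nM
compound 2, `CCCc1ccc(NC2=CC(=O)c3c(nc4n3[C@H]3OC[C@@H](O)[C@H]3OC4)C2=O)cc1`: > 4000 nM, a limit of the assay, not a number
compound 3, `O=C1C(Nc2ccccc2F)=CC(=O)c2c1nc1n2[C@H]2OC[C@@H](O)[C@H]2OC1`: 2660 nM

All three share one core and differ only in the group on the amine nitrogen, tested in a functional assay on ECa-109 cells for inhibition, with ECa-109 cell line (Homo sapiens) as the target, read by sulforhodamine B assay; on this read-out lower numbers stand for stronger inhibition and higher numbers for weaker inhibition. Compound 1 gives 2300 nM, the lowest of the two numbers shown. Compound 3 sits close at 2660 nM, within the scatter, so neither can be called stronger. For compound 2 the assay reports only a limit, > 4000 nM; this is the limit of > 4000 nM in this assay, at which 1 of the 3 values shown sits.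

The unmeasured compound 4, `CCOc1ccc(NC2=CC(=O)c3nc4n(c3C2=O)[C@H]2OC[C@@H](O)[C@H]2OC4)cc1`, differs from compound 1 as follows: ethoxy in place of iodo on an aromatic carbon. Cut one bond further out, this reads 4-iodophenyl to 4-ethoxyphenyl. Going by the values given here, the one measured step, an at least 1.5-fold lower number from compound 2 to compound 3 (0.17 log units; that floor lies within the scatter), alters a different part of the ring and bears only loosely on this change. Compound 1, with 4-iodophenyl, gives a number. Compound 2, with 4-propylphenyl, reaches only a limit.

Compound 4 is therefore estimated at 3500 nM, with a range from 1800 nM to 8000 nM. This estimate means a 1.5-fold higher number from compound 1 to compound 4 (0.18 log units; within the scatter), a step expected to stay within the scatter, with a fair chance of only a limit.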

Compound 4, half-maximal inhibitory concentration: 3210 nM
Compound 4: middle estimate off by 1.1-fold (0.04 log units), on the high side; the measured number falls inside the stated range.
By their numbers in this assay, from the lowest: compounds 1, 3 and 4 (each within the scatter of the next). At a limit, above all of these: compound 2.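

In this assay, replacing iodo with ethoxy on the aromatic carbon gives a 1.4-fold higher number from compound 1 to compound 4 (0.14 log units; within the scatter), so the two compounds cannot be told apart. Going by these compounds alone, until now, no pair of compounds with numbers had tested this position directly, and this pair shows that the number stays within the scatter when 1 heavy atom gives way to 3, including a hydrogen-bond acceptor that iodo does not have. Compound 2, which carries 4-propylphenyl at the same position, has only a limit and not a number, so this one comparison does not settle how it relates to the other compounds: the limit of > 4000 nM in this assay, at which 1 of the 4 values shown sits.

The compounds shown leave open whether any group at this position can move the number beyond the scatter, for example an amine, a carboxylic acid or a longer alkoxy chain such as butoxy. Within the data shown here, they also cannot say why iodo and ethoxy read alike, since a single pair within the scatter shows only that this swap left no measurable difference in this assay.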